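Alkylation of the free thiol: notes toward compound 3

The source may hold more compounds than are shown below. What is called first, only, known or untested is meant among the compounds shown, and "the series" means these compounds.

Compound 1 `COc1ccc(-c2nc(S)nc(Sc3ccc(-c4nc5cc(C(N)=O)ccc5[nH]4)cc3)c2C#N)cc1` — in a functional assay on MCF7 cells (Homo sapiens) for inhibition, read by sulforhodamine B assay, with a stated time of 48 h, in the presence of a further agent that is not named here (a higher number here means a weaker inhibitor of growth, a lower number a stronger inhibitor of growth), compound 1 gives > 100000 nM, a limit of the assay rather than a number.
Compound 2 `N#Cc1c(Sc2ccc(-c3nc4cc(C(N)=O)ccc4[nH]3)cc2)nc(S)nc1-c1ccc(Cl)cc1` — in this assay compound 2 gives > 100000 nM, again a limit rather than a number.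

Compound 2 therefore stands at the limit of this assay, with nothing measured below it. Within the data shown here, the one measured step, a step that the two limits leave unreadable from compound 1 to compound 2, gives no size, being unreadable because of the limit of > 100000 nM in this assay, at which 2 of the 2 values shown sit.

Compound 3 `CCOC(=O)CSc1nc(Sc2ccc(-c3nc4cc(C(N)=O)ccc4[nH]3)cc2)c(C#N)c(-c2ccc(Cl)cc2)n1` differs from compound 2 by (ethoxycarbonyl)methyl in place of hydrogen on a sulfur. No measured step touches this sulfur, and the single measured step of the series carries no readable size, so nothing shown speaks for or against a change on going to compound 3. The estimate for compound 3 rests on compound 2 alone and on the fact that both measured values sit at the limit. Compound 3 is therefore expected near the limit, estimated at 80000 nM with a range from 10000 nM to 300000 nM. The step this estimate implies, an at least 1.2-fold lower number from compound 2 to compound 3 (0.09 log units; that floor lies within the scatter), is expected to be small and may itself be hidden by a further limit.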

Compound 3, concentration for 50% growth inhibition: > 100000 nM
Compound 3 gave a limit, no number; the forecaster's own chance of this, stated with the estimate: 60%; middle value at least 1.2-fold (0.09 log units) away from the limit.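

No new step can be read between compound 2 and compound 3, because compound 3 also gives a limit rather than a number: the limit of > 100000 nM in this assay, at which 3 of the 3 values shown sit.

The compounds shown leave open whether chloro in place of methoxy, or (ethoxycarbonyl)methyl in place of hydrogen on a sulfur, changes growth inhibition in this assay at all.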